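Bromophenyl shift from compound 3 to compound 4

The compounds below may be only part of what the source reports. "The series", "measured", "known", "first", "only" and "open" are said of these compounds alone.

compound 1 `COc1ccccc1C(=O)n1c(-c2cn(C)c3ccc(Br)cc23)nc2ccccc21`: 34600 nM
compound 2 `COc1ccc(C(=O)n2c(-c3cn(C)c4ccc(Br)cc34)nc3ccccc32)cc1OC`: 9700 nM
compound 3 `Cn1cc(-c2nc3ccccc3n2C(=O)c2ccccc2Br)c2cc(Br)ccc21`: 72100 nM

All three values come from a functional assay on HepG2 cells (Homo sapiens) for inhibition, read by MTT assay, with a stated time of 24 h; a higher number here means a weaker inhibitor of growth, a lower number a stronger inhibitor of growth. Compound 3 has the highest number of the three, which makes it the weakest inhibitor of growth in this small set. The steps leading to it are a 2.1-fold higher number from compound 1 to compound 3 (0.32 log units; beyond the scatter) and a 7.4-fold higher number from compound 2 to compound 3 (0.87 log units; beyond the scatter).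

The next compound is compound 4 `Cn1cc(-c2nc3ccccc3n2C(=O)c2cccc(Br)c2)c2cc(Br)ccc21`, not yet measured. The change is 3-bromophenyl in place of 2-bromophenyl on a carbonyl carbon. Among the measured compounds shown here, no measured step moves a bromo group on its own, so the evidence is indirect. The closest guide is a 3.6-fold lower number from compound 1 to compound 2 (0.55 log units; beyond the scatter), which replaces 2-methoxyphenyl with 3,4-dimethoxyphenyl. The 2-methoxyphenyl compound 1 and the 2-bromophenyl compound 3 both have higher numbers than the 3,4-dimethoxyphenyl compound 2. However, those comparisons also change the groups themselves, and three compounds support only a tentative reading. A modest step towards a lower number is therefore expected in this assay, of about the size seen on going to compound 2, with no change beyond the scatter remaining possible.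

The expected change is a 2.4-fold lower number from compound 3 to compound 4 (0.38 log units; beyond the scatter). For compound 4 the estimated value is 30000 nM, with an expected range of 10000 nM to 75000 nM.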

Compound 4, concentration for 50% growth inhibition: 67300 nM
The estimate for compound 4 lay 2.2-fold (0.35 log units) below the measured number; low and high end bracket the measured number.
By their numbers in this assay, from the lowest: compound 2; then compounds 1, 4 and 3 (each within the scatter of the next, the first and the last beyond it).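

In this assay, among the compounds shown here, the bromo group changes place on its own for the first time, and the result is a 1.1-fold lower number from compound 3 to compound 4 (0.03 log units; within the scatter), so 2-bromophenyl and 3-bromophenyl on this carbonyl carbon cannot be told apart here. The 3-bromophenyl group also gives a 1.9-fold higher number from compound 1 to compound 4 (0.29 log units; within the scatter), leaving it indistinguishable from the 2-methoxyphenyl group in compound 1. The 3,4-dimethoxyphenyl group remains separate, with a 6.9-fold higher number from compound 2 to compound 4 (0.84 log units; beyond the scatter), so among these four compounds the change of bromo placement does not reproduce the lower number of compound 2, which stands at 9700 nM in this series.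

No measurement among these data accounts for either the flat bromo step or the separate standing of compound 2. Still open, as far as these compounds go, is whether the lower number of compound 2 needs both methoxy groups or is reached with a single one, as in 3-methoxyphenyl or 4-methoxyphenyl, and whether a 4-bromophenyl, an aminophenyl or a carboxyphenyl group on the same carbonyl carbon would separate from the bromophenyl pair.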